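The source may hold more compounds than are shown below. What is called first, only, known or untested is meant among the compounds shown, and "the series" means these compounds.

Compound 1 `O=C(O)c1ccc(-c2ccc(Cl)cc2COc2ccc(-c3nc4cc(C(=O)O)ccc4n3C3CCCCC3)cc2)cc1`: > 50000 nM
Compound 2 `CC(=O)c1ccc(-c2ccc(Cl)cc2)c(COc2ccc(-c3nc4cc(C(=O)O)ccc4n3C3CCCCC3)cc2)c1`: 24000 nM

These values come from a functional assay on Huh-5-2 cells (Homo sapiens), read by MTT assay; on this read-out higher numbers stand for lower toxicity in this test and lower numbers for higher toxicity in this test. For compound 1, > 50000 nM is a limit of the assay and not a number. Going by the values given here, that leaves compound 2, at 24000 nM, as the only exact number so far. Compound 3 `N#Cc1ccc(-c2ccc(Cl)cc2)c(COc2ccc(-c3nc4cc(C(=O)O)ccc4n3C3CCCCC3)cc2)c1` differs from compound 2 in one place: cyano in place of acetyl on an aromatic carbon. In short, it has cyano in place of acetyl on an aromatic carbon. Among the compounds with values here, no measured step shows the effect of this swap, so a change within the usual scatter is expected in this assay. The estimated step is a 1.2-fold higher number from compound 2 to compound 3 (0.07 log units; within the scatter). The expected value for compound 3 is 28000 nM, with an estimated range of 12000 nM to 50000 nM.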

Compound 3, half-maximal cytotoxic concentration: 23000 nM
Estimate against measurement, compound 3: 1.2-fold (0.09 log units) above, within the range that was stated.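

The swap of cyano for acetyl on this aromatic carbon gives a 1.0-fold lower number from compound 2 to compound 3 (0.02 log units; within the scatter) in this assay. At this position, then, these two groups cannot be told apart by this test. Going by these compounds alone, both values are exact numbers, so the step can be read directly, and only one value shown is a limit: the limit of > 50000 nM in this assay, at which 1 of the 3 values shown sits.

Still open, going by these compounds, is whether an amine or a longer carbon chain on the same carbon would shift the number beyond the scatter. On these data alone, whether any group here can do so remains unknown.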